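Notes on a nitrile-for-fluorine swap in the series

This account rests on a few compounds, and the source may have more. Where it says the series, first, only, none or still open, it means among the compounds named here.

Measured in an in vitro functional assay on HEK293 cells for antagonist activity at melanin-concentrating hormone receptor 1 (Homo sapiens), read by GTPgammaS binding, with a stated time of 45 min; on this read-out lower numbers stand for lower potency and higher numbers for higher potency (the scale is a negative logarithm):
compound 1 `Cc1ccc(CN2CCC(CCN(Cc3ccc(-c4ccc(F)cc4)cc3)C(=O)NC(C)C)CC2)cc1` gives 6.42
compound 2 `Cc1ccc(CN2CCC(CCN(Cc3ccc(-c4cccc(C#N)c4)cc3)C(=O)NC(C)C)CC2)cc1` gives 6
compound 3 `Cc1ccc(CN2CCC(CCN(Cc3ccc(-c4ccc(F)cc4)cc3)C(=O)NC(C)(C)CO)CC2)cc1` gives 7.39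

Two single changes on the core of compound 1 are covered. The first, (3-cyanophenyl in place of 4-fluorophenyl on an aromatic carbon), gave a number 0.42 log units lower from compound 1 to compound 2 (beyond the scatter). The second, (hydroxymethyl in place of hydrogen on a saturated chain carbon bound to an amide-type nitrogen and two saturated chain carbons), gave a number 0.97 log units higher from compound 1 to compound 3 (beyond the scatter), so that in this assay compound 3 stands highest of the three, its nearest neighbour being compound 1.

Compound 4 `Cc1ccc(CN2CCC(CCN(Cc3ccc(-c4cccc(C#N)c4)cc3)C(=O)NC(C)(C)CO)CC2)cc1` has not yet been measured. It differs from compound 3 by 3-cyanophenyl in place of 4-fluorophenyl on an aromatic carbon, at the same place as the change from compound 1 to compound 2, so the two are the same change on two cores; how those cores differ is the hydroxymethyl-for-hydrogen difference already told. Going by the values given here, only one instance of this change is measured, and nothing shows whether it behaves alike on the hydroxymethyl-bearing core.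

Compound 4 is expected to give 6.97 in this assay, with a likely span from 6.5 to 7.4. Among the compounds with values here, that expectation means a number 0.42 log units lower from compound 3 to compound 4 (beyond the scatter), and it rests on the one measured precedent because the only such step is a number 0.42 log units lower from compound 1 to compound 2 (beyond the scatter).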

Compound 4, negative logarithm of the antagonist equilibrium constant: 7.08
Estimate against measurement, compound 4: 0.11 log units below; the range from low to high includes it.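

In this assay, the swap to 3-cyanophenyl from 4-fluorophenyl also lowers the number on the hydroxymethyl-bearing core, a number 0.31 log units lower from compound 3 to compound 4 (beyond the scatter), and its size carries across the two cores: the same change on two cores in this assay, a number 0.42 log units lower (beyond the scatter) from compound 1 to compound 2 and a number 0.31 log units lower (beyond the scatter) from compound 3 to compound 4, 0.11 log units apart, within the scatter of two such steps.

Read along the other edge, the hydroxymethyl-for-hydrogen change also carries over to the 3-cyanophenyl core, a number 1.08 log units higher from compound 2 to compound 4 (beyond the scatter), and agrees with its earlier instance: the same change on two cores in this assay, a number 0.97 log units higher (beyond the scatter) from compound 1 to compound 3 and a number 1.08 log units higher (beyond the scatter) from compound 2 to compound 4, 0.11 log units apart, within the scatter of two such steps.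

Across these four compounds the two changes therefore behave as independent, but this is a single matched set on one shared core, so it does not show that the swap would transfer to other cores, and it gives no reason for either step.

The compounds shown leave open whether the same step would hold with a longer chain or a carboxylic acid in place of the hydroxymethyl group. They also leave open how a trifluoromethyl or methoxy group in place of the nitrile would fare on either core.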